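A few compounds are considered here, and "the series" means these few. Any claim that something is new, unique, unknown or untested is made for them only; others in the source may bear on it.

Four compounds built around an aromatic amide joined to an unsaturated ketone are compared in a functional assay on the whole organism (strain albino) for inhibition, with Rattus norvegicus as the target, read by paw edema, with stated times of 30 min and 4 h, at a dose of 100 mg/kg by the oral route; on this read-out higher numbers stand for more inhibition at the one dose given (going by the name of the read-out) and lower numbers for less inhibition. Compound 1 `COc1ccc(/C=C/C(=O)c2ccc(NC(=O)C(C)O[N+](=O)[O-])cc2)cc1` gives 43% in this assay. Compound 2 `CC(O[N+](=O)[O-])C(=O)Nc1ccc(C(=O)/C=C/c2ccco2)cc1` differs from it by furan-2-yl in place of 4-methoxyphenyl on a double-bonded chain carbon bound to a double-bonded chain carbon, and in this assay compound 2 gives 49%. The resulting step, a number 6 percentage points higher from compound 1 to compound 2 (within the scatter), is a small one. Compound 3 `COc1ccc(/C=C/C(=O)c2ccc(NC(=O)COCc3c(-c4ccccc4)no[n+]3[O-])cc2)cc1` carries a different core from compound 1; the difference between the two cores is not broken down here. In this assay compound 3 gives 55%, a number whose gap to compound 1 lies beyond the usual scatter, while its gap to compound 2 does not. Compound 4 `O=C(COCc1c(-c2ccccc2)no[n+]1[O-])Nc1ccc(C(=O)/C=C/c2ccco2)cc1` has not yet been measured in this assay. It differs from compound 3 by furan-2-yl in place of 4-methoxyphenyl on a double-bonded chain carbon bound to a double-bonded chain carbon, the same change that separates compound 1 from compound 2, made at the same place. Since that change produced only a number 6 percentage points higher from compound 1 to compound 2 (within the scatter) in this assay, the step expected here is also small, estimated as a number 5 percentage points higher from compound 3 to compound 4 (within the scatter). Because the same change gave a number 6 percentage points higher from compound 1 to compound 2 (within the scatter), compound 4 is expected to give about 60% in this assay, with a likely range of 48% to 72%. This rests on a single measured pair, so the expectation is held loosely until the measurement is made.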

Compound 4, a percentage reported as inhibition, in the whole organism at one dose (the size of the read-out at that dose, not a potency): 58%
The estimate for compound 4 lay 2 percentage points above the measured number, within the range that was stated.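

Putting furan-2-yl in place of 4-methoxyphenyl on the second core gives a number 3 percentage points higher from compound 3 to compound 4 (within the scatter) in this assay. Set beside the earlier step, the change looks the same on the two cores, with no difference between them that can be told apart from the scatter of such measurements: the same change on two cores in this assay, a number 6 percentage points higher (within the scatter) from compound 1 to compound 2 and a number 3 percentage points higher (within the scatter) from compound 3 to compound 4, 3 percentage points apart, within the scatter of two such steps

This shows that, for these two pairs, the change carries from one core to the other without any sign that the core alters its outcome, but it does not show that the change itself raises inhibition, since neither step rises above the scatter, and two small steps cannot show that it would behave the same way on any further core in the series.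

The compounds shown leave open how other groups would fare on a double-bonded chain carbon bound to a double-bonded chain carbon, such as a plain phenyl, a thiophen-2-yl or a pyridin-3-yl ring, where only 4-methoxyphenyl and furan-2-yl appear here. They also leave open whether a core carrying an amine or a carboxylic acid on the chain of the amide would take the same change as quietly as these two cores do.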